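A few compounds are considered here, and "the series" means these few. Any claim that something is new, unique, unknown or untested is made for them only; others in the source may bear on it.

Compound 1 `N[C@@H](COP(=O)(O)OCCCOC(=O)CCc1ccccc1OCc1cccc(Oc2ccccc2)c1)C(=O)O` gives 0.48 in an assay on cells for activation of probable G-protein coupled receptor 34 (Mus musculus), with a stated time of 1 h; a higher number here means a larger maximal response, a lower number a smaller maximal response. Compound 2 `Cc1cccc(Oc2cccc(COc3ccccc3CCC(=O)OCCCOP(=O)(O)OC[C@H](N)C(=O)O)c2)c1` gives 0.29 in this assay. Compound 3 `N[C@@H](COP(=O)(O)OCCCOC(=O)CCc1ccccc1OCc1cccc(Oc2cccc(Cl)c2)c1)C(=O)O` gives 0.53 in this assay.

Of the three, compound 3 has the highest number, though its gap to compound 1 lies within the scatter, while it stands clearly above compound 2. Compound 4 `N[C@@H](COP(=O)(O)OCCCOC(=O)CCc1ccccc1OCc1cccc(Oc2ccc(F)cc2)c1)C(=O)O` differs from compound 3 by 4-fluorophenyl in place of 3-chlorophenyl on an oxygen on an aromatic ring. Going by the values given here, two measured steps touch this part of the structure: a number 0.050 higher from compound 1 to compound 3 (within the scatter) and a number 0.24 higher from compound 2 to compound 3 (beyond the scatter). Neither swaps one halogen-bearing ring for another, so the new change is only loosely covered. Because a number 0.050 higher from compound 1 to compound 3 (within the scatter) was within the scatter, only a small step down is expected for compound 4: a number 0.080 lower from compound 3 to compound 4 (within the scatter). Compound 4 is therefore estimated at 0.45, within 0.3 to 0.6.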

Compound 4, intrinsic activity: the largest response reached, as a fraction of the reference agonist's: 0.66
For compound 4 the middle estimate is 0.21 below the measured one; measured number outside the range, above it.
By their numbers in this assay, from the lowest: compound 2; then compounds 1 and 3 (each within the scatter of the next); then compound 4.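

On the oxygen on an aromatic ring, 4-fluorophenyl gives the largest maximal response of the four rings: a number 0.13 higher from compound 3 to compound 4 (beyond the scatter), a number 0.37 higher from compound 2 to compound 4 (beyond the scatter), and a number 0.18 higher from compound 1 to compound 4 (beyond the scatter). The last step shows that a single fluoro group on the plain phenyl ring can move the response beyond the scatter, which chloro in compound 3 did not do. Nothing measured here explains the rise.

Halogen and ring position change together between compound 3 and compound 4, so their shares remain unseparated. As far as these compounds go, how 3-fluorophenyl or 4-chlorophenyl would behave at this place remains open.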